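A few compounds are considered here, and "the series" means these few. Any claim that something is new, unique, unknown or untested is made for them only; others in the source may bear on it.

Working notes on the series. Compound 1 `Cc1nnsc1CO/N=C/c1c(C)nn(C)c1Oc1ccc(F)cc1` carries the methyl chain together with the 4-fluorophenyl group; in a functional assay on PANC-1 cells (Homo sapiens) for inhibition, read by MTT assay, with a stated time of 48 h (on this read-out higher numbers stand for weaker inhibition and lower numbers for stronger inhibition), compound 1 gives only a limit, > 50000 nM. Compound 2 `CCc1nnsc1CO/N=C/c1c(C)nn(C)c1Oc1ccccc1Cl` likewise reaches only a limit in this assay, > 50000 nM. Compound 3 `CCCc1nnsc1CO/N=C/c1c(C)nn(C)c1Oc1ccccc1Cl` also stands at a limit in this assay, > 50000 nM. The step that the two limits leave unreadable from compound 2 to compound 3 therefore cannot be read. The change to compound 4 `CCCc1nnsc1CO/N=C/c1c(C)nn(C)c1Oc1ccc(F)cc1` is 4-fluorophenyl in place of 2-chlorophenyl on an oxygen on an aromatic ring. Among the compounds with values here, no measured step covers this exchange; compound 1 shows the 4-fluorophenyl group resting at the limit, and the limit of > 50000 nM in this assay, at which 3 of the 3 values shown sit, gives the same picture across the whole set so far. The step that the limit leaves unreadable from compound 3 to compound 4 is expected to leave compound 4 at the limit as well. Compound 4 is estimated at 60000 nM, with a range of 20000 nM to 200000 nM.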

Compound 4, half-maximal inhibitory concentration: > 50000 nM
Compound 4: only a limit was reported; the forecaster's own chance of this, stated with the estimate: 85%; the middle value is on the limit's open side.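

Compound 4 also stands at a limit, and neither its pair with compound 1 nor its pair with compound 3 yields a readable step. The compounds shown leave open whether any chain or phenyl-group exchange changes inhibition at all.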